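The source may report more compounds than this note shows. Statements on the series, on what has been measured and on what is new or still open speak of the compounds shown alone.

Two compounds have been measured in a functional assay on MCF7 cells (Homo sapiens) for cytotoxicity, read by MTT assay, with a stated time of 72 h; on this read-out higher numbers stand for weaker inhibition and lower numbers for stronger inhibition:

Compound 1, `O=C(NC(=S)NNc1ncnc2ccccc12)c1ccc(C(F)(F)F)cc1`, gives 8050 nM.
Compound 2, `COc1cc2ncnc(NNC(=S)NC(=O)c3ccc(F)cc3)c2cc1OC`, gives 25800 nM.

Compound 1 stands at the lower of the two numbers, which on this read-out means the stronger inhibition of the two. Compound 2 sits at a higher number, and the gap between them is beyond the usual scatter of repeated measurements. The two compounds differ in more than one place, so what separates them is not traced to a single change; only the two values themselves can be compared.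

Compound 3, `O=C(NC(=S)NNc1ncnc2ccccc12)c1ccc(Cl)cc1`, has not yet been measured in this assay. It differs from compound 1 in one place: chloro in place of trifluoromethyl on an aromatic carbon. The change sits on an aromatic carbon of a six-membered aromatic ring of carbon only, para to a large group; the rest of the molecule, including the shared core, is unchanged.

For the measured compounds named here, no measured pair here isolates this kind of exchange, so there is no measured step to lean on. For a small change of one group for another at the same place, the expected step from compound 1 to compound 3 is a 1.1-fold higher number from compound 1 to compound 3 (0.05 log units; within the scatter), that is, none beyond the scatter in either direction. Compound 3 is therefore expected to give about 9000 nM, within a range from 3500 nM to 25000 nM.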

Compound 3, half-maximal inhibitory concentration: 5960 nM
Compound 3: middle estimate off by 1.5-fold (0.18 log units), on the high side; the range from low to high includes it.
By their numbers in this assay, from the lowest: compounds 3 and 1 (each within the scatter of the next); then compound 2.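

Putting chloro in place of trifluoromethyl on this aromatic carbon gives a 1.4-fold lower number from compound 1 to compound 3 (0.13 log units; within the scatter) in this assay, so the two compounds cannot be told apart on this read-out. This is the first pair shown that differs in only one place, and it gives a first direct look at this position: a single chlorine atom stands where a group of four heavy atoms stood, with no change beyond the scatter. No measurement shown here accounts for the two groups reading alike.

The compounds shown leave open whether the number would also stay in this region with a quite different group at the same place, such as an amine, a carboxylic acid or a longer chain, since only two groups can be compared directly at this position so far. They also leave open whether chloro and trifluoromethyl would read alike on another core, including the core of compound 2, or in any assay other than this assay.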